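The compounds below may be only part of what the source reports. "The series", "measured", "known", "first", "only" and "open" are said of these compounds alone.

Of the compounds shown here, two have been measured so far in an assay on cells for inhibition of MAP kinase-interacting serine/threonine-protein kinase 1 (Homo sapiens), read by mobility shift assay, with stated times of 10 min and 60 min, in the presence of a further agent that is not named here; a higher number here means a weaker inhibitor, a lower number a stronger inhibitor. Compound 1, `NCCOc1cc(-c2cccnc2)ccc1C(N)=O`, carries a 2-aminoethoxy chain on its core; in this assay compound 1 gives 820 nM. Compound 2, `Cn1cc(-c2cncc(-c3ccc(C(N)=O)cc3)c2)cn1`, is built on a different core; in this assay compound 2 gives 800 nM. The two numbers lie within the usual scatter of this kind of measurement, so they cannot be told apart, and compound 1 counts as neither stronger nor weaker than compound 2 on the evidence at hand.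

Compound 3, `CCOc1cc(-c2cccnc2)ccc1C(N)=O`, has not yet been measured. It is compound 1 with one change: hydrogen in place of amino on a saturated chain carbon, two bonds along the chain from an oxygen on an aromatic ring. Within the data shown here, no pair of measured compounds shows what this change does, so any expectation rests on the change itself. Taking away the amino group removes one hydrogen-bond donor and one hydrogen-bond acceptor from the chain, and with nothing in the measured set to anchor it, only a modest shift toward a weaker inhibitor is expected, possibly none beyond the scatter. For compound 3 the estimate in this assay is 1300 nM, with a plausible range from 450 nM to 4000 nM, which would mean an expected step of a 1.6-fold higher number from compound 1 to compound 3 (0.20 log units; within the scatter).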

Compound 3, half-maximal inhibitory concentration: 2200 nM
Compound 3: the middle estimate sits 1.7-fold (0.23 log units) below what was measured; the range from low to high includes it.
By their numbers in this assay, from the lowest: compounds 2 and 1 (each within the scatter of the next); then compound 3.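

In this assay, hydrogen in place of amino on this saturated chain carbon, two bonds along the chain from an oxygen on an aromatic ring, gives a 2.7-fold higher number from compound 1 to compound 3 (0.43 log units; beyond the scatter). Among these compounds, this is the first step that can be read beyond the usual scatter, and it shows that the change from 2-aminoethoxy to ethoxy registers in this assay, though only modestly. With the amino group gone, compound 3 is the weaker inhibitor of this pair, but no accompanying measurement shows what lies behind the step.

Among the compounds shown here, a single pair shows only that the amino group and hydrogen differ at this place, so it remains open whether another end group, such as a hydroxyl, a dimethylamino group or a carboxylic acid, would behave like the amino group or like hydrogen. Also open, going by these compounds, is what a longer chain, such as 3-aminopropoxy, would do, and whether the same change would have a step of similar size on a different core.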